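Compound 3: a phenyl group exchanged on the shared core

The source may hold more compounds than are shown below. What is called first, only, known or untested is meant among the compounds shown, and "the series" means these compounds.

In a physicochemical assay for solubility, in phosphate buffer, measured as kinetic solubility, at pH 7.4 (on this read-out lower numbers stand for lower solubility and higher numbers for higher solubility), compound 1 `Cc1ccc(C)c(-c2nc(CN3CCC(C(=O)NCCCN4C[C@H](C)C[C@H](C)C4)CC3)c(C)o2)c1` gives 56.1 ug/mL as a measured number. Compound 2 `COc1cccc(Br)c1-c1nc(CN2CCC(C(=O)NCCCN3C[C@H](C)C[C@H](C)C3)CC2)c(C)o1` stands at > 83 ug/mL as a limit and not a number. Compound 3 `Cc1ccc(-c2nc(CN3CCC(C(=O)NCCCN4C[C@H](C)C[C@H](C)C4)CC3)c(C)o2)cc1` has 4-methylphenyl in place of 2-bromo-6-methoxyphenyl on an aromatic carbon and is unmeasured. For the measured compounds named here, the one measured step at this place is an at least 1.4-fold higher number from compound 1 to compound 2 (0.17 log units; that floor lies within the scatter) and its floor lies within the scatter. Going by the values given here, the expectation rests on compound 1 at 56.1 ug/mL as the only measured number, so a move to a lower number, or none beyond the scatter, is expected in this assay for compound 3. The estimated step is an at least 1.3-fold lower number from compound 2 to compound 3 (0.14 log units; that floor lies within the scatter) in size. Compound 3 is estimated at 60 ug/mL with an expected range of 28 ug/mL to 95 ug/mL on this read-out.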

Compound 3, solubility: > 69 ug/mL
Compound 3 gave a limit, no number; the forecaster's own chance of this, stated with the estimate: 25%; at least 1.1-fold (0.06 log units) between middle value and limit.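

In this assay, compound 3 stands as a limit and not a number, so 4-methylphenyl joins 2-bromo-6-methoxyphenyl as a second group at this position that reads only as a limit. The exchange of 2,5-dimethylphenyl for 4-methylphenyl is an at least 1.2-fold higher number from compound 1 to compound 3 (0.08 log units; that floor lies within the scatter), so this floor shows no change beyond the scatter. The step between the two limits cannot be read.

Still open, as far as these compounds go, is how far compound 2 and compound 3 lie past their limits. Also open, from the compounds shown here alone, is whether an amine or a carboxylic acid on the phenyl group at this position would give a measured number.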